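Swapping the Benzylic Aryl Group in a Weak Amine Oxidase Series

The compounds below may be only part of what the source reports. "The series", "measured", "known", "first", "only" and "open" are said of these compounds alone.

Three compounds share one core and differ only in the aromatic group attached on a saturated chain carbon bound to an amine nitrogen in a ring. Compound 1 `Cc1ccccc1CN1CCC(CCNC(=O)/C=C/c2cc(C(C)(C)C)c(O)c(C(C)(C)C)c2)CC1` was tested in an assay on isolated protein for inhibition of Amine oxidase [flavin-containing] A (Homo sapiens), read by fluorescence, with stated times of 15 min and 20 min (on this read-out lower numbers stand for stronger inhibition and higher numbers for weaker inhibition), where compound 1 gives 69300 nM. Compound 2 `CC(C)(C)c1cc(/C=C/C(=O)NCCC2CCN(Cc3cccc(F)c3)CC2)cc(C(C)(C)C)c1O` gives 58400 nM, and compound 3 `CC(C)(C)c1cc(/C=C/C(=O)NCCC2CCN(Cc3ccc(F)cc3F)CC2)cc(C(C)(C)C)c1O` gives 70600 nM. On the numbers shown, compound 1 stands second highest of the three, with compound 3 nearest and compound 2 furthest, and every step stays within the scatter: a 1.2-fold lower number from compound 1 to compound 2 (0.07 log units; within the scatter), a 1.0-fold higher number from compound 1 to compound 3 (0.01 log units; within the scatter) and a 1.2-fold higher number from compound 2 to compound 3 (0.08 log units; within the scatter). Compound 4 `CC(C)(C)c1cc(/C=C/C(=O)NCCC2CCN(Cc3cccc([N+](=O)[O-])c3)CC2)cc(C(C)(C)C)c1O` is not yet measured. It differs from compound 1 in one place: 3-nitrophenyl in place of 2-methylphenyl on a saturated chain carbon bound to an amine nitrogen in a ring. All three measured steps bear on this position: each exchanges one aromatic group there for another, and none moves the number beyond the scatter. Within the data shown here, no measured compound carries a nitro group; what that group does here is unknown. A step of about the same size is therefore expected, a 1.1-fold lower number from compound 1 to compound 4 (0.03 log units; within the scatter), with no direction beyond the scatter. Compound 4 is expected to give 65000 nM, with a range from 30000 nM to 140000 nM.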

Compound 4, half-maximal inhibitory concentration: 70900 nM
Beside the measured number, compound 4's estimate is 1.1-fold (0.04 log units) below it; low and high end bracket the measured number.
By their numbers in this assay, from the lowest: compounds 2, 1, 3 and 4 (each within the scatter of the next).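

Among these compounds, the 3-nitrophenyl group is the first group at this position to carry hydrogen-bond acceptors, and it has more heavy atoms than the 2-methylphenyl group it replaces, yet in this assay the result is a 1.0-fold higher number from compound 1 to compound 4 (0.01 log units; within the scatter). Set against the other two groups, the outcome is the same, with a 1.0-fold higher number from compound 3 to compound 4 (0.00 log units; within the scatter) and a 1.2-fold higher number from compound 2 to compound 4 (0.08 log units; within the scatter). All four compounds therefore lie within the scatter of one another, and nothing measured here offers a reason for this flat picture.

On these data alone, all four groups are substituted phenyl rings, so it remains open whether a group of another kind on this chain carbon, such as a cyclohexyl ring, a carboxylic acid or an amine, would move the number beyond the scatter. As far as these compounds go, whether changes to the shared core would do so also remains open.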